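Phenyl in place of hydroxymethyl on compound 1

A few compounds are considered here, and "the series" means these few. Any claim that something is new, unique, unknown or untested is made for them only; others in the source may bear on it.

Within the data shown here, in a functional assay on SK-N-SH cells (Homo sapiens) for inhibition, read by MTT assay, with a stated time of 72 h, tested at 50 uM (a higher number here means more inhibition of growth at the concentration tested, a lower number less inhibition of growth), compound 1 `C=CCc1cc(O)c(O)c(CN2CCC(CCO)CC2)c1` gives 40.6% as the lower of the two numbers so far. Compound 2 `C=CCc1ccc(OCc2cn(-c3ccc(OC)cc3)nn2)c(O)c1` stands higher at 68.5% and this gap lies beyond the scatter. Compound 3 `C=CCc1cc(O)c(O)c(CN2CCC(Cc3ccccc3)CC2)c1` is still unmeasured and differs from compound 1 by phenyl in place of hydroxymethyl on a saturated chain carbon bound to a saturated ring carbon with phenyl in place of hydroxymethyl on a saturated chain carbon bound to a saturated ring carbon. Among the measured compounds shown here, no measured step between close relatives is available to size this change. In this assay, for the measured compounds named here, an upward step beyond the scatter is expected, although the value of compound 2 at 68.5% shows only that higher numbers occur. The estimated move is a number 17.4 percentage points higher from compound 1 to compound 3 (beyond the scatter) on this reading, and it remains uncertain. Compound 3 is expected at 58% with an estimated range of 40% to 78% for now.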

Compound 3, percent growth inhibition at one concentration: 83.4%
Beside the measured number, compound 3's estimate is 25.4 percentage points below it, and the stated range ends below it.
By their numbers in this assay, from the lowest: compound 1; then compound 2; then compound 3.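

In this assay, putting phenyl in place of hydroxymethyl on a saturated chain carbon bound to a saturated ring carbon gives a number 42.8 percentage points higher from compound 1 to compound 3 (beyond the scatter), a large step and the only one sized so far. Read one bond further out, the same difference is 2-hydroxyethyl to benzyl, and it shows that this one change, with the rest of the core of compound 1 kept, can move growth inhibition well beyond the usual scatter. No measurement at hand accounts for the size of this step.

This single pair cannot separate the entry of the aromatic ring from the loss of the hydroxyl group. On these data alone, a cyclohexyl group or a plain ethyl group in this place would speak to that, and the effect of an amine or a carboxylic acid here remains open.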